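The source may report more compounds than this note shows. Statements on the series, on what has been measured and on what is new or still open speak of the compounds shown alone.

Measured so far:
- Compound 1, `Cc1c(Cl)cccc1CCCCOc1ccc(C#Cc2cccc3c(CCCC(=O)O)c(C)n(CC(=O)O)c23)cc1`: 3.2 10^-6 cm/s
- Compound 2, `Cc1c(Cl)cccc1CCCCOc1ccc(C#Cc2cccc3c(CCCC(=O)O)c(C)n(CCC(=O)O)c23)cc1`: 3 10^-6 cm/s
- Compound 3, `Cc1c(Cl)cccc1CCCCOc1ccc(C#Cc2cccc3c(CCCC(=O)O)c(C)n(CCCCC(=O)O)c23)cc1`: 5 10^-6 cm/s

In a physicochemical assay for permeability, using PAMPA, with a stated time of 4 h, at pH 7.4, tested at 50 uM (a lower number here means that the compound crosses the layer more slowly, a higher number that the compound crosses the layer faster), compound 1 gives 3.2 10^-6 cm/s, the second highest of the three numbers; its nearest neighbour is compound 2 and its furthest is compound 3, and both of those gaps lie within the scatter. The unmeasured compound 4, `Cc1c(Cl)cccc1CCCCOc1ccc(C#Cc2cccc3c(CC(=O)O)c(C)n(CC(=O)O)c23)cc1`, differs from compound 1 in the chain on the aromatic carbon of the core: carboxy in place of 2-carboxyethyl on a saturated chain carbon bound to an aromatic carbon.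

Going by the values given here, none of the measured steps touches that chain. What has been measured is the chain on the aromatic nitrogen, where a 1.1-fold lower number from compound 1 to compound 2 (0.03 log units; within the scatter), a 1.6-fold higher number from compound 1 to compound 3 (0.19 log units; within the scatter) and a 1.7-fold higher number from compound 2 to compound 3 (0.22 log units; within the scatter) all stayed within the scatter. Lengthening or shortening one acid-bearing chain on this core thus gave no step beyond the scatter in this assay, and the change in compound 4 is a comparable cut on the other chain. On that basis compound 4 is expected to sit close to compound 1, with a 1.1-fold lower number from compound 1 to compound 4 (0.03 log units; within the scatter), no step beyond the scatter. The estimate for compound 4 is 3 10^-6 cm/s, in a range from 1.5 10^-6 cm/s to 6 10^-6 cm/s.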

Compound 4, apparent permeability: < 0.05 10^-6 cm/s
Compound 4 ended at the assay's limit; the forecaster's own chance of this, stated with the estimate: 5%; at least 60-fold (1.77 log units) between middle value and limit.
By their numbers in this assay, from the lowest: compounds 2, 1 and 3 (each within the scatter of the next). At a limit, below all of these: compound 4.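

The reading for compound 4 in this assay is a limit of the assay and not a number: the limit of < 0.05 10^-6 cm/s in this assay, at which 1 of the 4 values shown sits. Even so, the change from 3-carboxypropyl to carboxymethyl on a saturated chain carbon bound to an aromatic carbon gives an at least 64-fold lower number from compound 1 to compound 4 (1.80 log units; beyond the scatter), the first step in this series that lies beyond the scatter. On the chain on the aromatic nitrogen, compound 1, compound 2 and compound 3 differ only within the scatter, so the two acid-bearing chains do not behave alike, and the length of the chain on the aromatic carbon matters here in a way that the length of the chain on the nitrogen did not.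

The compounds shown leave open whether a 2-carboxyethyl chain at this position would keep the number of compound 1 or already fall to the limit, and whether the same cut would act as strongly with the longer 3-carboxypropyl chain of compound 3 on the nitrogen. They also leave open whether the carboxylic acid itself is involved, as a methyl ester or a primary amide in its place on the short chain would show.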